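Aryl variation in a thiosemicarbazone series, ovarian cytotoxicity

The compounds below may be only part of what the source reports. "The series", "measured", "known", "first", "only" and "open" are said of these compounds alone.

Compound 1 `CC1=CC[C@@H]([C@@](C)(O)CCCC(C)(C)NC(=S)N/N=C\c2ccc(C)cc2)CC1`: 45300 nM
Compound 2 `COc1ccc(/C=N\NC(=S)NC(C)(C)CCC[C@](C)(O)[C@@H]2CC=C(C)CC2)cc1`: 46200 nM
Compound 3 `CC1=CC[C@@H]([C@@](C)(O)CCCC(C)(C)NC(=S)N/N=C\c2cccc([N+](=O)[O-])c2)CC1`: > 100000 nM

In a functional assay on OVCAR-3 cells (Homo sapiens) for cytotoxicity, read by sulforhodamine B assay (on this read-out lower numbers stand for higher toxicity in this test and higher numbers for lower toxicity in this test), compound 1 gives 45300 nM and compound 2 gives 46200 nM; between them a 1.0-fold higher number from compound 1 to compound 2 (0.01 log units; within the scatter). For compound 3 the reading > 100000 nM is a limit of the assay rather than a number. Compound 3 thus sits at the limit of > 100000 nM in this assay, at which 1 of the 3 values shown sits. Compound 4 `CC1=CC[C@@H]([C@@](C)(O)CCCC(C)(C)NC(=S)N/N=C\c2ccccc2Cl)CC1` differs from compound 3 in 2-chlorophenyl in place of 3-nitrophenyl on a carbon with a double bond to nitrogen. The steps that swapped the aryl group are an at least 2.2-fold higher number from compound 1 to compound 3 (0.34 log units; beyond the scatter) and an at least 2.1-fold higher number from compound 2 to compound 3 (0.33 log units; beyond the scatter); both moved onto the 3-nitrophenyl, so leaving it is expected to run the other way. The expected step is an at least 1.6-fold lower number from compound 3 to compound 4 (0.22 log units; that floor lies within the scatter), bringing compound 4 back toward the values of compounds 1 and 2. Compound 4 is estimated at 60000 nM, range 25000 nM to 150000 nM.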

Compound 4, concentration lethal to 50% of the cells: > 100000 nM
Compound 4: no number, only a limit (the forecaster's own chance of this, stated with the estimate: 30%); middle value at least 1.6-fold (0.22 log units) away from the limit.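

In this assay compound 4 gives > 100000 nM, a limit of the assay and not a number. On the carbon with a double bond to nitrogen, 2-chlorophenyl departs from the 4-methoxyphenyl and 4-methylphenyl with an at least 2.1-fold higher number from compound 2 to compound 4 (0.33 log units; beyond the scatter) and an at least 2.2-fold higher number from compound 1 to compound 4 (0.34 log units; beyond the scatter), so this move is not peculiar to 3-nitrophenyl. The step between compound 3 and compound 4 cannot be read, since both values are limits.

On these data alone, how far either compound lies past the limit stays open. Also open, as far as these compounds go, is whether a 4-chlorophenyl or 4-aminophenyl here would stay near compound 1 and compound 2 or reach the limit.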